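This account rests on a few compounds, and the source may have more. Where it says the series, first, only, none or still open, it means among the compounds named here.

In a functional assay on HT-29 cells (Homo sapiens) for cytotoxicity, read by resazurin assay, with a stated time of 48 h (on this read-out lower numbers stand for an effect already at smaller amounts and higher numbers for an effect only at larger amounts of compound), compound 1 (`COc1ccc(S(=O)(=O)Nc2ccc(-c3nc4cc(NS(=O)(=O)c5ccc(OC)cc5)ccc4o3)cc2)cc1`) gives 40000 nM and compound 2 (`COc1ccc(S(=O)(=O)Nc2ccc3oc(-c4ccc(NS(=O)(=O)c5cc(Br)ccc5OC)cc4)nc3c2)cc1`) gives 14000 nM as the lower of the two numbers. Compound 3 (`COc1ccc(S(=O)(=O)Nc2ccc3oc(-c4ccc(NC(=O)C5CCN(C(C)=O)CC5)cc4)nc3c2)cc1`) differs from compound 2 at one place ((1-acetylpiperidin-4-yl)carbonyl in place of (5-bromo-2-methoxyphenyl)sulfonyl on a nitrogen on an aromatic ring). For the measured compounds named here, only one measured step bears on this place, and it was modest (a 2.9-fold lower number from compound 1 to compound 2 (0.46 log units; beyond the scatter)), so a step of similar size toward a higher number is expected (a 2.1-fold higher number from compound 2 to compound 3 (0.33 log units; beyond the scatter)). That guide is loose: the measured step only swapped one methoxyphenyl group for another. In this assay compound 3 is estimated at 30000 nM (expected range 10000 nM to 90000 nM).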

Compound 3, half-maximal effective concentration: 16000 nM
Compound 3: the middle estimate sits 1.9-fold (0.27 log units) above what was measured; low and high end bracket the measured number.
By their numbers in this assay, from the lowest: compounds 2 and 3 (each within the scatter of the next); then compound 1.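

In this assay, an aromatic ring in the group on this nitrogen is not needed to hold the number: putting (1-acetylpiperidin-4-yl)carbonyl in place of (5-bromo-2-methoxyphenyl)sulfonyl gives a 1.1-fold higher number from compound 2 to compound 3 (0.06 log units; within the scatter), so these two groups cannot be told apart here. Measured against (4-methoxyphenyl)sulfonyl, the same group gives a 2.5-fold lower number from compound 1 to compound 3 (0.40 log units; beyond the scatter), a modest step. Nothing available explains these results. Still open, from the compounds shown here alone, is whether a free amine on the piperidine ring, in place of the acetyl group, or a carboxylic acid would shift the number. A simple open chain on this nitrogen, with no ring at all, is equally untested by these compounds.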